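Removing One Catechol Hydroxyl from a Dienone Inhibitor

The compounds below may be only part of what the source reports. "The series", "measured", "known", "first", "only" and "open" are said of these compounds alone.

Measured compounds:
- compound 1, `Oc1ccc(CC[C@H]2C[C@@H](O)C[C@@H](c3ccc(O)cc3)O2)cc1`, 39700 nM
- compound 2, `O=C(/C=C/C=C/c1ccc(O)c(O)c1)CCc1ccc(O)c(O)c1`, 7840 nM

Of the compounds shown here, two have been tested in a functional assay on BV-2 cells (Mus musculus) for inhibition, read by Griess assay, with a stated time of 24 h; a lower number here means a stronger inhibitor, a higher number a weaker inhibitor. Compound 1, `Oc1ccc(CC[C@H]2C[C@@H](O)C[C@@H](c3ccc(O)cc3)O2)cc1`, gives 39700 nM. Compound 2, `O=C(/C=C/C=C/c1ccc(O)c(O)c1)CCc1ccc(O)c(O)c1`, gives 7840 nM, the lowest of the two numbers; the gap to compound 1 lies beyond the usual scatter of this assay.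

Compound 3, `O=C(/C=C/C=C/c1ccc(O)c(O)c1)CCc1ccc(O)cc1`, has not yet been measured. It differs from compound 2 by a single change: hydrogen in place of hydroxy on an aromatic carbon. Among the measured compounds shown here, only two measurements exist, so no step of this kind has been observed directly, and the expectation rests on the change itself.

With one hydroxy group gone from compound 2, a modest weakening is expected, a 1.9-fold higher number from compound 2 to compound 3 (0.28 log units; within the scatter), a step likely somewhat beyond the scatter but well short of the gap between compound 1 and compound 2. Compound 3 is therefore estimated at 15000 nM, within a range of 6000 nM to 40000 nM.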

Compound 3, half-maximal inhibitory concentration: 14400 nM
For compound 3 the middle estimate is 1.0-fold (0.02 log units) above the measured one; the range from low to high includes it.
By their numbers in this assay, from the lowest: compounds 2 and 3 (each within the scatter of the next); then compound 1.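

In this assay, among the compounds shown here, going from 3,4-dihydroxyphenyl to 4-hydroxyphenyl gives a 1.8-fold higher number from compound 2 to compound 3 (0.26 log units; within the scatter) and provides the first direct reading of this single change. Because the step lies within the scatter, compound 2 and compound 3 cannot be placed in order, and the hydroxy group at this place, ortho to a hydroxy group, is not shown to matter for the inhibition read here. No supporting evidence is available to account for the size of this step.

The compounds shown leave open whether a methoxy group or a fluorine atom at this place would read differently from hydroxy or hydrogen. They also leave open whether the same change on the remaining 3,4-dihydroxyphenyl group, or loss of the remaining hydroxy group on the changed ring, would give a step beyond the scatter.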